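Notes on the step from compound 2 to compound 4

The source may report more compounds than this note shows. Statements on the series, on what has been measured and on what is new or still open speak of the compounds shown alone.

Compound 1, `COc1ccc(NC(=O)CNCCCC(=O)Nc2ccccc2N)cc1`: compound 1 gives 44000 nM in a functional assay on HCT-116 cells (Homo sapiens) for inhibition, read by MTT assay, with a stated time of 2 days; a lower number here means a stronger inhibitor of growth, a higher number a weaker inhibitor of growth.
Compound 2, `Nc1ccccc1NC(=O)CCCNCC(=O)Nc1cc(Cl)ccc1Cl`: compound 2 gives 78000 nM in this assay.
Compound 3, `COc1ccc(NC(=O)CNc2ccc(C(=O)Nc3ccccc3N)cc2)cc1`: compound 3 gives 38000 nM in this assay.

Compound 2 carries the highest number of the three; its gap to compound 1 is within the scatter, its gap to compound 3 is beyond it. Compound 4, `Nc1ccccc1NC(=O)CCCNCC(=O)Nc1cccc([N+](=O)[O-])c1`, differs from compound 2 by 3-nitrophenyl in place of 2,5-dichlorophenyl on an amide-type nitrogen. For the measured compounds named here, the only step that bears on this is the one on the same amide-type nitrogen, a 1.8-fold higher number from compound 1 to compound 2 (0.25 log units; within the scatter), which stayed within the scatter. With only that to go on, no step beyond the scatter is expected in this assay, and the estimate for compound 4 is 60000 nM, range 25000 nM to 150000 nM, corresponding to an expected step of a 1.3-fold lower number from compound 2 to compound 4 (0.11 log units; within the scatter).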

Compound 4, concentration for total growth inhibition: 22500 nM
Beside the measured number, compound 4's estimate is 2.7-fold (0.43 log units) above it; the whole stated range lies above it.
By their numbers in this assay, from the lowest: compounds 4, 3, 1 and 2 (each within the scatter of the next, the first and the last beyond it).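

In this assay, this amide-type nitrogen now shows a step beyond the scatter, a 3.5-fold lower number from compound 2 to compound 4 (0.54 log units; beyond the scatter), whereas the earlier step there, a 1.8-fold higher number from compound 1 to compound 2 (0.25 log units; within the scatter), stayed within it. The other new step, a 2.0-fold lower number from compound 1 to compound 4 (0.29 log units; within the scatter), stays within the scatter, so 3-nitrophenyl separates from 2,5-dichlorophenyl but not from 4-methoxyphenyl. No measurement at hand accounts for the step from 2,5-dichlorophenyl to 3-nitrophenyl.

Open, as far as these compounds go, is how an unsubstituted phenyl or an aminophenyl would compare on this nitrogen. Also open, from the compounds shown here alone, is whether 3-nitrophenyl gives a similar step on the core of compound 3.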